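Chloropurine benzyl series: amino step on cytotoxicity

This account rests on a few compounds, and the source may have more. Where it says the series, first, only, none or still open, it means among the compounds named here.

Measured so far:
compound 1 `ClCc1ccc(Cn2cnc3c(Cl)ncnc32)cc1`: 2340 nM
compound 2 `Nc1nc(Cl)c2ncn(Cc3ccc(CCl)cc3)c2n1`: 3160 nM
compound 3 `ClCc1ccccc1Cn1cnc2c(Cl)ncnc21`: 10700 nM

In a functional assay on SF-539 cells (Homo sapiens) for cytotoxicity, read by sulforhodamine B assay, with a stated time of 48 h (on this read-out lower numbers stand for stronger inhibition of growth and higher numbers for weaker inhibition of growth), compound 1 gives 2340 nM and compound 2 gives 3160 nM. The two differ by one change, (amino in place of hydrogen on an aromatic carbon), and the step is a 1.4-fold higher number from compound 1 to compound 2 (0.13 log units; within the scatter).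

Compound 3 `ClCc1ccccc1Cn1cnc2c(Cl)ncnc21` gives 10700 nM in this assay, the highest of the three numbers; it differs from compound 1 in the arrangement of the same atoms, and the difference between the two cores is not broken down here.

Compound 4 `Nc1nc(Cl)c2ncn(Cc3ccccc3CCl)c2n1` is not yet measured in this assay. It differs from compound 3 by amino in place of hydrogen on an aromatic carbon, the same change that separates compound 1 from compound 2: the place lines of the two changes agree word for word, so this is the same change made on a second core. It occurs in two pairs among the compounds shown.

Among the compounds with values here, the expectation for compound 4 rests on the one measured example: the amino step from compound 1 to compound 2 gave a 1.4-fold higher number from compound 1 to compound 2 (0.13 log units; within the scatter), and a step of the same size is expected on the core of compound 3, so a 1.3-fold higher number from compound 3 to compound 4 (0.12 log units; within the scatter) is the estimated step. Compound 4 is thus expected to give 14000 nM in this assay, with a range from 7000 nM to 30000 nM estimated. Within the data shown here, there is only one prior example of this change, so the range is kept wide.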

Compound 4, concentration for 50% growth inhibition: 18200 nM
Compound 4: middle estimate off by 1.3-fold (0.11 log units), on the low side; the measured number falls inside the stated range.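

In this assay, amino in place of hydrogen on an aromatic carbon gives a 1.7-fold higher number from compound 3 to compound 4 (0.23 log units; within the scatter), and this second step can be set beside the first: the same change on two cores in this assay, a 1.4-fold higher number (0.13 log units; within the scatter) from compound 1 to compound 2 and a 1.7-fold higher number (0.23 log units; within the scatter) from compound 3 to compound 4, 1.3-fold (0.10 log units) apart, within the scatter of two such steps. On these two cores the change therefore carries over in a plain sense: neither step can be told from no change, and the two steps cannot be told from each other. This does not establish a rule for the series, since it rests on two pairs only, and steps this small show that the amino group leaves the read-out within the scatter on both cores, not that any real shift of a fixed size is being carried from one core to the other.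

The compounds shown leave open whether a different group in the same place, such as a methylamino group, a hydroxyl group or a methoxy group, would stay as close to the hydrogen compounds as the amino group does. They also leave open whether the agreement between the two steps holds on any further core, or in any read-out other than this assay.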